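A Methyl Enters Where Ethyl and Chloro Were Tried

The compounds below may be only part of what the source reports. "The series", "measured", "known", "first", "only" and "open" are said of these compounds alone.

Measured so far in a physicochemical assay for lipophilicity, read by mass spectrometry; on this read-out lower numbers stand for lower lipophilicity and higher numbers for higher lipophilicity:
- compound 1, `COc1cc2c(cc1OC)C(=O)C(C(=O)Nc1ccccc1)C2`, gives 2.2
- compound 2, `CCc1cccc(NC(=O)C2Cc3cc(OC)c(OC)cc3C2=O)c1`, gives 3.11
- compound 3, `COc1cc2c(cc1OC)C(=O)C(C(=O)Nc1cccc(Cl)c1)C2`, gives 2.76

All three share the same core and differ only in one group on the aromatic ring at the amide end. Compound 1, which carries nothing extra there, stands lowest of the three in this assay: a number 0.56 log units higher from compound 1 to compound 3 (beyond the scatter), and a number 0.91 log units higher from compound 1 to compound 2 (beyond the scatter). Between the two substituted compounds, a number 0.35 log units lower from compound 2 to compound 3 (beyond the scatter), so the ethyl group raised the number more than the chloro did.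

Compound 4, `COc1cc2c(cc1OC)C(=O)C(C(=O)Nc1ccccc1C)C2`, is the next step from compound 1: methyl in place of hydrogen on an aromatic carbon. The two steps that bear on it are the ethyl and chloro additions, both of which raised the number by a modest amount. A methyl brings one carbon where ethyl brought two, so a rise is expected, smaller than that for ethyl. For compound 4 the expected step is a number 0.50 log units higher from compound 1 to compound 4 (beyond the scatter). Compound 4 is therefore estimated at 2.7, within 2.4 to 3.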

Compound 4, partition coefficient: 2.69
For compound 4 the middle estimate is 0.01 log units above the measured one; the range from low to high includes it.
By their numbers in this assay, from the lowest: compound 1; then compounds 4 and 3 (each within the scatter of the next); then compound 2.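

In this assay, for the compounds shown here, a single methyl ortho to a large group gives a clear rise, a number 0.49 log units higher from compound 1 to compound 4 (beyond the scatter) and so a group in this place, which no earlier compound carried, also moves the number upward. Swapping 3-chlorophenyl for 2-methylphenyl, which changes the group and its place together, gives a number 0.07 log units lower from compound 3 to compound 4 (within the scatter) while swapping 3-ethylphenyl for 2-methylphenyl gives a number 0.42 log units lower from compound 2 to compound 4 (beyond the scatter) and so the one-carbon methyl matches the chloro compound but not the ethyl compound on this read-out. Nothing among the data shown accounts for these steps.

Among the compounds shown, no single group appears in two places on this ring, so the effect of place alone cannot be separated from the effect of the group. On these data alone, how an amine or a carboxylic acid at this ring position would shift the number also remains open.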